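A few compounds are considered here, and "the series" means these few. Any claim that something is new, unique, unknown or untested is made for them only; others in the source may bear on it.

Measured so far in an assay for inhibition of serine/threonine-protein kinase PAK 4 (Homo sapiens), read by FRET and Z'-LYTE, with a stated time of 60 min, tested at 0.5 uM, in the presence of a further agent that is not named here; on this read-out higher numbers stand for a stronger effect at the one concentration tested and lower numbers for a weaker effect:
Compound 1 `CCCCCOC(=O)N1CCN(C(=O)c2nc(Nc3cc(C4CC4)[nH]n3)c3cc(Cl)ccc3n2)C[C@H]1C`: -3.8%
Compound 2 `CC(C)OC(=O)N1CCN(C(=O)c2nc(Nc3cc(C4CC4)[nH]n3)c3cc(Cl)ccc3n2)C[C@H]1C`: 26.9%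
Compound 3 `C[C@@H]1CN(C(=O)c2nc(Nc3cc(C4CC4)[nH]n3)c3cc(Cl)ccc3n2)CCN1C(=O)OCOC(=O)C(C)(C)C`: 0.7%

Compound 2 stands highest of the three numbers; compound 3 comes nearest and compound 1 lies furthest, both beyond the scatter. Compound 4 `CC(OC(=O)N1CCN(C(=O)c2nc(Nc3cc(C4CC4)[nH]n3)c3cc(Cl)ccc3n2)C[C@H]1C)OC(=O)C(C)(C)C` is drawn from compound 2 by one change: ((tert-butyl)carbonyl)oxy in place of methyl on a saturated chain carbon bound to an oxygen next to a carbonyl group and a saturated chain carbon. The step that bears on it is a number 26.2 percentage points lower from compound 2 to compound 3 (beyond the scatter), which also brings a ((tert-butyl)carbonyl)oxy unit into the group on the oxygen next to the carbonyl; a number 4.5 percentage points higher from compound 1 to compound 3 (within the scatter) adds that this unit and butyl sit within the scatter of each other. A drop of roughly the size seen in a number 26.2 percentage points lower from compound 2 to compound 3 (beyond the scatter) is therefore expected in this assay, namely a number 23.9 percentage points lower from compound 2 to compound 4 (beyond the scatter). Compound 4 is estimated at 3%, between -12% and 18%.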

Compound 4, a percentage reported as inhibition, at one concentration (the size of the read-out at that concentration, not a potency): -6.9%
Compound 4: middle estimate off by 9.9 percentage points, on the high side, and the stated range covers the measured number.
By their numbers in this assay, from the lowest: compounds 4, 1 and 3 (each within the scatter of the next); then compound 2.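

In this assay the exchange of methyl for ((tert-butyl)carbonyl)oxy on this saturated chain carbon goes with a large fall (a number 33.8 percentage points lower from compound 2 to compound 4 (beyond the scatter)). Adding methyl to the carbon bound to two oxygens does not recover the number of compound 2, as this step stays within the scatter (a number 7.6 percentage points lower from compound 3 to compound 4 (within the scatter)). The full 1-(((tert-butyl)carbonyl)oxy)ethyl group also stays within the scatter of pentyl (a number 3.1 percentage points lower from compound 1 to compound 4 (within the scatter)).

No evidence is available to explain this result. On these data alone, whether a smaller methoxy or ethyl group on this carbon would keep the number of compound 2 remains open.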